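The source may hold more compounds than are shown below. What is called first, only, known or untested is meant among the compounds shown, and "the series" means these compounds.

In a functional assay on MOLT-4 cells (Homo sapiens) for antiproliferative activity, with a stated time of 48 h (on this read-out lower numbers stand for stronger inhibition and higher numbers for weaker inhibition), compound 1 `C=C(Br)C(=O)Nc1ccc(C(=O)/C=C/c2ccccc2)cc1` gives 500 nM, and compound 2 `C=C(Br)C(=O)Nc1ccc(C(=O)/C=C/c2ccc(OC)cc2)cc1` gives 610 nM. These two numbers lie within the scatter of each other, so compound 2 stands level with compound 1 on the values available. Compound 3 `C=C(Br)C(=O)Nc1ccc(C(=O)/C=C/c2ccc(OC)c(OC)c2)cc1` differs from compound 2 in one place: methoxy in place of hydrogen on an aromatic carbon. This is methoxy in place of hydrogen on an aromatic carbon, ortho to a methoxy group. Within the data shown here, the one measured step of the same kind is a 1.2-fold higher number from compound 1 to compound 2 (0.09 log units; within the scatter), and it stayed within the scatter. Among the measured compounds shown here, it is thin evidence, since it is a single step and no measured compound carries two methoxy groups. For the measured compounds named here, with that step as the only guide, no change beyond the scatter is expected in this assay. The expected step is a 1.0-fold lower number from compound 2 to compound 3 (0.01 log units; within the scatter). Compound 3 is estimated at 600 nM, with an expected range from 250 nM to 1400 nM.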

Compound 3, half-maximal inhibitory concentration: 1800 nM
Compound 3: middle estimate off by 3.0-fold (0.48 log units), on the low side; measured number above the stated range.
By their numbers in this assay, from the lowest: compounds 1 and 2 (each within the scatter of the next); then compound 3.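

In this assay, methoxy in place of hydrogen ortho to a methoxy group gives a 3.0-fold higher number from compound 2 to compound 3 (0.47 log units; beyond the scatter), a step beyond the scatter. The same kind of change earlier gave a 1.2-fold higher number from compound 1 to compound 2 (0.09 log units; within the scatter), which stayed within the scatter, so the size of that first step did not carry over to this position. Nothing at hand gives a reason for the larger step.

Going by these compounds, it remains open whether this step depends on the methoxy group already present, or whether methoxy at this position would give a similar step on the core of compound 1. On these data alone, it is also open whether the step belongs to methoxy in particular, or whether a hydroxyl, a fluorine atom or an amine at this position would give a number nearer that of compound 2.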